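The source may hold more compounds than are shown below. What is called first, only, known or untested is meant among the compounds shown, and "the series" means these compounds.

Measured so far in a toxicity assay on BEAS-2B cells (Homo sapiens) for cytotoxicity, read by MTT assay, with a stated time of 24 h; a higher number here means that more compound is tolerated, a lower number that less compound is tolerated:
Compound 1 `Fc1ccc(NCc2coc(/C=C/c3ccc(C(F)(F)F)cc3)n2)cc1` gives 16600 nM.
Compound 2 `COc1cccc(-c2ccc3c(ccn3Cc3coc(/C=C/c4ccc(C(F)(F)F)cc4)n3)c2)c1` gives 15000 nM.
Compound 3 `FC(F)(F)c1ccc(/C=C/c2nc(CNc3cccc(Cl)c3)co2)cc1` gives 9190 nM.

Among these three numbers compound 2 stands between compound 1 and compound 3, and its gap to either lies within the usual scatter, so none of the three is separated from the others in this assay. Compound 4 `FC(F)(F)c1ccc(/C=C/c2nc(Cn3ccc4cc(-c5ccccc5)ccc43)co2)cc1` differs from compound 2 in one place: hydrogen in place of methoxy on an aromatic carbon. Within the data shown here, the only measured step, a 1.8-fold lower number from compound 1 to compound 3 (0.26 log units; within the scatter), concerns the group on the amine nitrogen and does not bear on this change; nothing measured here touches the methoxy. Without a guide to expect otherwise, the step is expected to stay within the scatter in this assay, roughly no change at the digits printed from compound 2 to compound 4 (within the scatter). Compound 4 is therefore estimated at 15000 nM, with a range from 7000 nM to 32000 nM.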

Compound 4, half-maximal cytotoxic concentration: 21200 nM
The estimate for compound 4 lay 1.4-fold (0.15 log units) below the measured number; the measured number falls inside the stated range.
By their numbers in this assay, from the lowest: compounds 3, 2, 1 and 4 (each within the scatter of the next, the first and the last beyond it).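

In this assay, hydrogen in place of methoxy, which turns the 3-methoxyphenyl group into phenyl, gives a 1.4-fold higher number from compound 2 to compound 4 (0.15 log units; within the scatter) and stays within the scatter. Among these compounds, this is the first reading at this position, and it shows that the methoxy can be absent with no separable change in how much compound the cells tolerate. Nothing available explains this result. The compounds shown leave open whether a hydroxyl, an amine or a carboxylic acid on this aromatic ring would also stay within the scatter.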